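Swapping the heteroaryl on sulfur: expected cytotoxicity of compound 4

This account rests on a few compounds, and the source may have more. Where it says the series, first, only, none or still open, it means among the compounds named here.

Compound 1 `Cc1nnc(SCc2cc(=O)c3cc(Cl)ccc3o2)o1` was tested in a functional assay on MDA-MB-435S cells (Homo sapiens) for cytotoxicity, read by MTT assay, with a stated time of 72 h (on this read-out lower numbers stand for stronger inhibition and higher numbers for weaker inhibition), and gave only a limit, > 25000 nM. Compound 2 `Nc1nnc(SCc2cc(=O)c3cc(Cl)ccc3o2)s1` likewise reached only a limit in this assay, > 25000 nM. The change between them, (5-amino-1,3,4-thiadiazol-2-yl in place of 5-methyl-1,3,4-oxadiazol-2-yl on a sulfur), is therefore a step that a step that the two limits leave unreadable from compound 1 to compound 2; both values sit at the limit of > 25000 nM in this assay, at which 2 of the 3 values shown sit, so its size stays hidden. Compound 3 `Cc1nnc(SCc2coc3ccccc3c2=O)o1` has a core that differs from that of compound 1 in a way not broken down here. In this assay compound 3 gives 1200 nM. Compound 4 `Nc1nnc(SCc2coc3ccccc3c2=O)s1` carries the same kind of change, (5-amino-1,3,4-thiadiazol-2-yl in place of 5-methyl-1,3,4-oxadiazol-2-yl on a sulfur), on the core of compound 3. Within the data shown here, with the only comparable step unreadable, the expected step from compound 3 to compound 4 in this assay is a 2.5-fold higher number from compound 3 to compound 4 (0.40 log units; beyond the scatter), carrying wide uncertainty. Compound 4 is estimated at 3000 nM, between 700 nM and 20000 nM.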

Compound 4, half-maximal inhibitory concentration: 950 nM
Compound 4: middle estimate off by 3.2-fold (0.50 log units), on the high side, and the stated range covers the measured number.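

On the core of compound 3, putting 5-amino-1,3,4-thiadiazol-2-yl in place of 5-methyl-1,3,4-oxadiazol-2-yl on a sulfur gives a 1.3-fold lower number from compound 3 to compound 4 (0.10 log units; within the scatter) in this assay, so on this core the two groups cannot be told apart. On the core of compound 1, the same change cannot be read, since compound 1 and compound 2 each give only a limit: the limit of > 25000 nM in this assay, at which 2 of the 4 values shown sit. The series therefore offers one readable instance of this change, which does not show that it carries over from one core to another.

On these data alone, it remains open how this core would respond to a carboxylic acid or a longer chain in place of the methyl or the amino group on the ring. As far as these compounds go, whether a plain amine attached directly on the sulfur-bearing chain would read differently also stays open.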